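The compounds below may be only part of what the source reports. "The series", "measured", "known", "first", "only" and "open" are said of these compounds alone.

In a functional assay on HeLa cells (Homo sapiens) for antiproliferative activity, read by sulforhodamine B assay, with a stated time of 72 h (a lower number here means a stronger inhibitor, a higher number a weaker inhibitor), compound 1 `CN(C)C(=S)N/N=C/c1ccc2ccccc2n1` gives 90 nM. Compound 2 `COc1ccc(C)cc1NC(=S)N/N=C/c1ccc2ccccc2n1` gives > 100000 nM, which is a limit of the assay and not a number. Compound 3 `Cc1cccc(NC(=S)N/N=C/c2ccc3ccccc3n2)c1` gives > 100000 nM, which is also a limit. Compound 3 therefore has no exact number and stands at the limit of > 100000 nM in this assay, at which 2 of the 3 values shown sit.

Compound 4 `S=C(N/N=C/c1ccc2ccccc2n1)Nc1cccc(Br)c1` differs from compound 3 in one place, with bromo in place of methyl on an aromatic carbon. The change from 3-methylphenyl to 3-bromophenyl has not yet been tested in this assay. Among the measured compounds shown here, the only measured step close to it is a step that the two limits leave unreadable from compound 2 to compound 3, and it offers no size to carry over. Compound 1 lacks this substituted ring, so it says little about this change. Compound 4 is expected to stay weak, quite possibly reported as a limit again, with no clear move in either direction. The estimated step is a number no higher from compound 3 to compound 4 (the limit leaves the size open). For compound 4 the estimated value is 100000 nM, with an expected range from 20000 nM to 300000 nM.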

Compound 4, half-maximal inhibitory concentration: 70000 nM
For compound 4 the middle estimate is 1.4-fold (0.15 log units) above the measured one, and the stated range covers the measured number.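

Among the compounds shown here, compound 4 is the only compound here with a substituted phenyl ring that gives an exact number in this assay, so with bromo at this position the value comes within the readable range of the assay. Compound 3 gives > 100000 nM, which is a limit of the assay and not a number. Bromo in place of methyl therefore brings an at least 1.4-fold lower number from compound 3 to compound 4 (0.15 log units; that floor lies within the scatter), and only this floor can be read, not the true size of the change.

The step from compound 2 to compound 3 cannot be read, and part of the set still rests on a limit: the limit of > 100000 nM in this assay, at which 2 of the 4 values shown sit.

Going by these compounds, whether an amine or a carboxylic acid at this same position on the phenyl ring would give a lower number remains open.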